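From Ethyl Ester to Free Acid: An Expected Potency Shift

This account rests on a few compounds, and the source may have more. Where it says the series, first, only, none or still open, it means among the compounds named here.

Compound 1 `CCOC(=O)c1oc2ccc(N(Cc3ccccc3)S(=O)(=O)c3ccc(Br)cc3)cc2c1C` gives 9460 nM in a functional assay on HCT-116 cells (Homo sapiens) for inhibition, read by MTT assay, with a stated time of 72 h; a higher number here means a weaker inhibitor, a lower number a stronger inhibitor.
Compound 2 `CCOC(=O)c1oc2ccc(N(Cc3ccccc3)S(=O)(=O)c3ccccc3)cc2c1C` gives > 40000 nM in this assay, which is a limit of the assay rather than a number.

For the measured compounds named here, compound 1 holds the only numerical value in this assay; the other result is a limit (the limit of > 40000 nM in this assay, at which 1 of the 2 values shown sits). Going by the values given here, the single measured step, an at least 4.2-fold higher number from compound 1 to compound 2 (0.62 log units; beyond the scatter), concerns the bromo group on the aromatic ring. Compound 3 `Cc1c(C(=O)O)oc2ccc(N(Cc3ccccc3)S(=O)(=O)c3ccc(Br)cc3)cc12` differs from compound 1 elsewhere: hydrogen in place of ethyl on an oxygen next to a carbonyl group. Among the compounds with values here, no measured step touches this position, so the change from ethoxycarbonyl to carboxy is unanchored by the data. The expectation for compound 3 is therefore a weaker inhibition than compound 1, with a step of a 2.6-fold higher number from compound 1 to compound 3 (0.42 log units; beyond the scatter) that may push the result toward the limit. Compound 3 is estimated at 25000 nM, expected between 8000 nM and 60000 nM.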

Compound 3, half-maximal inhibitory concentration: 7090 nM
The estimate for compound 3 lay 3.5-fold (0.55 log units) above the measured number; measured number below the stated range.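

In this assay, the change from ethoxycarbonyl to carboxy now has a measured step, a 1.3-fold lower number from compound 1 to compound 3 (0.13 log units; within the scatter), so compound 1 and compound 3 cannot be told apart at this position. For the compounds shown here, replacing ethyl with hydrogen on this oxygen therefore leaves the reading within the usual scatter, and the change at the bromo group remains the only step beyond it. The one limit among the three compounds belongs to compound 2, and compound 3 gives a number rather than a limit: the limit of > 40000 nM in this assay, at which 1 of the 3 values shown sits.

The compounds shown leave open whether the carboxy group would give a similar reading on a core without the bromo group. They also leave open how a primary amide, or a longer chain on the ester oxygen, would read at this position.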